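Adding a hydroxy group to compound 2

A few compounds are considered here, and "the series" means these few. Any claim that something is new, unique, unknown or untested is made for them only; others in the source may bear on it.

Compound 2 `Cc1cn([C@H]2C[C@H](O)[C@@H](CO)O2)c(=O)n(/C=C/C=O)c1=O` gives 15000 nM in a functional assay on HeLa cells (Homo sapiens) for inhibition; a higher number here means a weaker inhibitor, a lower number a stronger inhibitor. Compound 3 `O=C/C=C/n1c(=O)c(I)cn([C@H]2C[C@H](O)[C@@H](CO)O2)c1=O` gives 15000 nM in this assay, and no change at the digits printed from compound 2 to compound 3 (within the scatter). For compound 1 `Cc1cn(/C=C/C#N)c(=O)[nH]c1=O` the result in this assay is a limit of the assay and not a number, > 100000 nM. That value sits at the limit of > 100000 nM in this assay, at which 1 of the 3 values shown sits. Compound 4 `Cc1cn([C@@H]2O[C@H](CO)[C@@H](O)[C@@H]2O)c(=O)n(/C=C/C=O)c1=O` has not yet been measured; it differs from compound 2 by hydroxy in place of hydrogen on a saturated ring carbon. Among the measured compounds shown here, the only measured step, no change at the digits printed from compound 2 to compound 3 (within the scatter), concerns a different group at a different place, so it bears on this change only loosely, and no measured step touches the five-membered non-aromatic ring. The account therefore expects no step beyond the scatter, a 1.3-fold higher number from compound 2 to compound 4 (0.12 log units; within the scatter). Compound 4 is estimated at 20000 nM, in a range from 6000 nM to 70000 nM.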

Compound 4, half-maximal inhibitory concentration: > 100000 nM
Compound 4: a limit, no number (the forecaster's own chance of this, stated with the estimate: 20%); at least 5.0-fold (0.69 log units) between middle value and limit.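

In this assay, among the compounds shown here, the ring of compound 2 now has a measured step, and it lies beyond the scatter: hydroxy in place of hydrogen on this saturated ring carbon gives an at least 6.6-fold higher number from compound 2 to compound 4 (0.82 log units; beyond the scatter), whereas the one earlier step, on an aromatic carbon, showed no change. Compound 4 gives a limit of the assay and not a number, so the step has a lower bound only: the limit of > 100000 nM in this assay, at which 2 of the 4 values shown sit.

The compounds shown leave open whether a different group on this ring carbon, such as fluoro, methoxy or an amine, would hold the value of compound 2. They also leave open how the same hydroxy would act alongside the iodo of compound 3.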